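A few compounds are considered here, and "the series" means these few. Any claim that something is new, unique, unknown or untested is made for them only; others in the source may bear on it.

In a functional assay on the whole organism (strain NMRI) with Mus musculus as the target, with a stated time of 0.5 h (on this read-out lower numbers stand for an effect already at smaller amounts and higher numbers for an effect only at larger amounts of compound), compound 1 `Cc1ccc(-c2nc3ccc(Br)cn3c2/C=N/OCc2cn(Cc3ccc([N+](=O)[O-])cc3)nn2)cc1` gives 20 mg/kg. Compound 2 `COc1ccc(Cn2cc(CO/N=C/c3c(-c4ccc(C)cc4)nc4c(C)cccn34)nn2)cc1`, which shares the same core but carries other groups at several points, gives 40 mg/kg in this assay. These two numbers lie within the usual scatter of one another, so the data do not separate the two compounds.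

Compound 3 `Cc1ccc(Cn2cc(CO/N=C/c3c(-c4ccc(C)cc4)nc4ccc(Br)cn34)nn2)cc1` has not yet been measured in this assay. It differs from compound 1 in one place: methyl in place of nitro on an aromatic carbon. Among the compounds with values here, no pair of measured compounds differs only in this way, so there is no measured step that tells what this exchange does. In the absence of such a step, the expectation is that compound 3 behaves much like compound 1, with a step of no change at the digits printed from compound 1 to compound 3 (within the scatter) that stays within the scatter. Compound 3 is therefore estimated to give 20 mg/kg in this assay, with a range from 10 mg/kg to 40 mg/kg.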

Compound 3, minimum effective dose: 40 mg/kg
The estimate for compound 3 lay 2.0-fold (0.30 log units) below the measured number, within the range that was stated.
By their numbers in this assay, from the lowest: compounds 1, 2 and 3 (each within the scatter of the next).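

Within the data shown here, replacing 4-nitrobenzyl with 4-methylbenzyl gives a 2.0-fold higher number from compound 1 to compound 3 (0.30 log units; within the scatter) in this assay, the first measured step for this exchange at this position. Nitro, with 3 heavy atoms and 2 hydrogen-bond acceptors, and methyl, with 1 heavy atom and no hydrogen-bond acceptors, give numbers that this assay does not separate in this pair, even though the two groups differ in these counts. Nothing measured here explains this outcome.

The compounds shown leave open whether an amine, a carboxylic acid or a longer chain at this position would give a number beyond the scatter. They also leave open whether the same exchange would read alike with the other groups found on compound 2.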